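Swapping one fluorinated group on compound 2

The compounds below may be only part of what the source reports. "The series", "measured", "known", "first", "only" and "open" are said of these compounds alone.

In a functional assay on CWR22R cells (Homo sapiens) for antiproliferative activity, read by propidium iodide staining, with a stated time of 96 h (on this read-out higher numbers stand for weaker inhibition and lower numbers for stronger inhibition), compound 1 (`CC(O)(CSc1ccc(C(F)(F)F)cc1)C(=O)Nc1ccc(S(F)(F)(F)(F)F)cc1`) gives 14800 nM and compound 2 (`CC(O)(COc1ccc(S(F)(F)(F)(F)F)cc1)C(=O)Nc1cc(C(F)(F)F)cc(C(F)(F)F)c1`) gives 3200 nM on the same read-out. Compound 2 thus holds the lower of the two numbers, and its gap to compound 1 lies beyond the scatter. The two compounds differ in more than one place, so their values point to no single change. Compound 3 (`CC(O)(COc1ccc(C(F)(F)C(F)(F)F)cc1)C(=O)Nc1cc(C(F)(F)F)cc(C(F)(F)F)c1`) departs from compound 2 in one place, with a group of 7 heavy atoms (2 carbon, 5 fluorine; no ring) in place of a group of 6 heavy atoms (5 fluorine, 1 sulfur; no ring), on an aromatic carbon as the change. The incoming 1,1,2,2,2-pentafluoroethyl group stands on an aromatic carbon of a six-membered aromatic ring of carbon only, para to a large group. Within the data shown here, no measured pair tests this swap. A step within the scatter is expected, with neither direction favoured, and the estimate amounts to a 1.1-fold higher number from compound 2 to compound 3 (0.04 log units; within the scatter) overall. In this assay compound 3 is estimated at 3500 nM with an expected range from 1500 nM to 8000 nM as its upper end.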

Compound 3, half-maximal inhibitory concentration: 2500 nM
The estimate for compound 3 lay 1.4-fold (0.15 log units) above the measured number; low and high end bracket the measured number.
By their numbers in this assay, from the lowest: compounds 3 and 2 (each within the scatter of the next); then compound 1.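

Among these compounds, the step of a 1.3-fold lower number from compound 2 to compound 3 (0.11 log units; within the scatter) in this assay is the first comparison here that isolates a single change. At this position, on an aromatic carbon of a six-membered aromatic ring of carbon only and para to a large group, the 1,1,2,2,2-pentafluoroethyl group and the group of five fluorines on sulfur cannot be told apart on this read-out. Compound 1 could not show this, as it differs from compound 2 in more than one place, and nothing available here offers an explanation for the outcome.

The compounds shown leave open how a nitrile, an amine or a longer perfluoroalkyl chain would fare at this position. Going by these compounds, it also remains open whether the same swap would stay within the scatter on the core of compound 1.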